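Aryl changes on the shared core: bromo to nitro

This account rests on a few compounds, and the source may have more. Where it says the series, first, only, none or still open, it means among the compounds named here.

In a functional assay on PC-3 cells (Homo sapiens) for cytotoxicity, read by sulforhodamine B assay, with a stated time of 48 h (on this read-out lower numbers stand for stronger inhibition and higher numbers for weaker inhibition), compound 1 (`C[C@H]1CC[C@@H]2[C@@H](OC(=O)[C@]23CC(c2c(Cl)cccc2Cl)=NO3)[C@]2(C)C(=O)C=C[C@@]12O`) gives 56000 nM and compound 2 (`COc1ccc(C2=NO[C@]3(C2)C(=O)O[C@@H]2[C@H]3CC[C@H](C)[C@]3(O)C=CC(=O)[C@@]23C)cc1`) gives 35000 nM while compound 3 (`C[C@H]1CC[C@@H]2[C@@H](OC(=O)[C@]23CC(c2ccccc2Br)=NO3)[C@]2(C)C(=O)C=C[C@@]12O`) gives 51000 nM so compound 3 sits level with both, within the scatter. Compound 4 (`C[C@H]1CC[C@@H]2[C@@H](OC(=O)[C@]23CC(c2ccccc2[N+](=O)[O-])=NO3)[C@]2(C)C(=O)C=C[C@@]12O`) differs from compound 3 by nitro in place of bromo on an aromatic carbon with nitro in place of bromo on an aromatic carbon, ortho to a large group. Three aryl changes on the carbon with a double bond to nitrogen bear on this: a 1.1-fold lower number from compound 1 to compound 3 (0.04 log units; within the scatter) and a 1.5-fold higher number from compound 2 to compound 3 (0.16 log units; within the scatter) and a 1.6-fold lower number from compound 1 to compound 2 (0.20 log units; within the scatter) all stay within the scatter, so no step beyond the scatter is expected in this assay here, though compound 1, compound 2 and compound 3 all lack nitro. a 1.1-fold lower number from compound 3 to compound 4 (0.05 log units; within the scatter) is the estimated step. Compound 4 is estimated at 45000 nM with an expected range from 22000 nM to 90000 nM in this estimate.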

Compound 4, half-maximal inhibitory concentration: 37000 nM
Compound 4: middle estimate off by 1.2-fold (0.09 log units), on the high side; low and high end bracket the measured number.
By their numbers in this assay, from the lowest: compounds 2, 4, 3 and 1 (each within the scatter of the next).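

Nitro in place of bromo on the aromatic carbon ortho to a large group, tested in this assay, gives a 1.4-fold lower number from compound 3 to compound 4 (0.14 log units; within the scatter) and so adds a second hydrogen-bond acceptor pair of atoms to this place without a step beyond the scatter. The 2-nitrophenyl group also stays level with the other aryl groups, with a 1.1-fold higher number from compound 2 to compound 4 (0.02 log units; within the scatter) and a 1.5-fold lower number from compound 1 to compound 4 (0.18 log units; within the scatter) as its steps. No supporting data explain this flat result.

On these data alone, whether an amine or a carboxylic acid on this aromatic ring would move the number beyond the scatter remains open.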